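A few compounds are considered here, and "the series" means these few. Any claim that something is new, unique, unknown or untested is made for them only; others in the source may bear on it.

Compound 1 `NCCCCCCc1c[nH]cn1` carries an amino group at the end of a saturated chain that runs from the aromatic core. In an assay on CHO cells for displacement of a labelled ligand from histamine H1 receptor (Cavia porcellus) (a lower number here means a stronger inhibitor, a higher number a weaker inhibitor), compound 1 gives 126000 nM. Compound 2 `NCCCCCCCCc1c[nH]cn1` differs from it only by a longer chain, and in this assay compound 2 gives 2510 nM. The lengthening brought a 50-fold lower number from compound 1 to compound 2 (1.70 log units; beyond the scatter). Among the two numbers measured so far, compound 2 therefore stands at the lowest, with compound 1 as its only neighbour at a much higher number.

Compound 3 `NCCCCCCCCCCc1c[nH]cn1` takes the same road one stage further: 2-aminoethyl in place of amino on a saturated chain carbon, eight bonds along the chain from an aromatic carbon. For the measured compounds named here, only one measured step bears on this change, the one from compound 1 to compound 2, and it was large and downward in this assay. Repeating the same chain extension is expected to lower the number again, though a second gain as large as the first cannot be counted on. The expected step is a 3.1-fold lower number from compound 2 to compound 3 (0.50 log units; beyond the scatter). Compound 3 is therefore estimated at 800 nM, within a range from 150 nM to 4000 nM.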

Compound 3, inhibition constant: 631 nM
The estimate for compound 3 lay 1.3-fold (0.10 log units) above the measured number; measured number inside the range.
By their numbers in this assay, from the lowest: compound 3; then compound 2; then compound 1.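

Replacing amino with 2-aminoethyl on a saturated chain carbon, eight bonds along the chain from an aromatic carbon, lowers the number in this assay once more (a 4.0-fold lower number from compound 2 to compound 3 (0.60 log units; beyond the scatter)), so the downward direction holds across all three compounds, and none of them goes against it. This second step is only modest where the first was large, which shows that the gain from the same change is not constant along this short series, even though the total change remains large (a 200-fold lower number from compound 1 to compound 3 (2.30 log units; beyond the scatter)). Nothing measured here explains why the longer chains give lower numbers or why the second gain is the smaller one.

Three compounds cannot show whether a longer chain than that of compound 3 would lower the number further, level off or reverse the direction. They also leave open how much depends on the amino group itself, a question that a hydroxyl group or a carboxylic acid in its place would address.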